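Swapping propyl for tert-butyl on a furan-3-yl ester

The compounds below may be only part of what the source reports. "The series", "measured", "known", "first", "only" and "open" are said of these compounds alone.

Compound 1, `CCCOC(=O)C1=C(C)N(C)C(=O)NC1c1ccco1`: 8% in an assay on membranes from HeLa cells for displacement of a labelled ligand from adenosine receptor A3 (Homo sapiens), read by scintillation counting, with a stated time of 180 min, tested at 1 uM; a higher number here means more inhibition at the concentration tested (going by the name of the read-out), a lower number less inhibition
Compound 2, `CC1=C(C(=O)OC(C)(C)C)C(c2ccco2)NC(=O)N1C`: 54% in this assay
Compound 3, `CCCOC(=O)C1=C(C)N(C)C(=O)NC1c1ccoc1`: 16% in this assay

Compound 3 stands second highest of these three numbers; the step of a number 8 percentage points higher from compound 1 to compound 3 (within the scatter) lies within the scatter, while compound 2 sits far above both. Compound 4, `CC1=C(C(=O)OC(C)(C)C)C(c2ccoc2)NC(=O)N1C`, differs from compound 3 by tert-butyl in place of propyl on an oxygen next to a carbonyl group. For the measured compounds named here, the one measured step that bears on this is a number 46 percentage points higher from compound 1 to compound 2 (beyond the scatter), the same change made on the furan-2-yl compounds, and it was large. A step of similar size, upward, is therefore expected in this assay for compound 4, estimated as a number 42 percentage points higher from compound 3 to compound 4 (beyond the scatter). Compound 4 is thus expected to give about 58%, within a range from 35% to 80%.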

Compound 4, a percentage reported as inhibition, at one concentration (the size of the read-out at that concentration, not a potency): 12%
Compound 4: the middle estimate sits 46 percentage points above what was measured; the measured number lies below the stated range.
By their numbers in this assay, from the lowest: compounds 1, 4 and 3 (each within the scatter of the next); then compound 2.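

On the furan-3-yl compounds, tert-butyl in place of propyl gives a number 4 percentage points lower from compound 3 to compound 4 (within the scatter), so the rise seen with furan-2-yl does not carry over: the same change on two cores in this assay, a number 46 percentage points higher (beyond the scatter) from compound 1 to compound 2 and a number 4 percentage points lower (within the scatter) from compound 3 to compound 4, 50 percentage points apart, beyond the scatter of two such steps. Read the other way, among the tert-butyl esters, furan-3-yl in place of furan-2-yl gives a number 42 percentage points lower from compound 2 to compound 4 (beyond the scatter), so this swap also depends on its partner: the same change on two cores in this assay, a number 8 percentage points higher (within the scatter) from compound 1 to compound 3 and a number 42 percentage points lower (beyond the scatter) from compound 2 to compound 4, 50 percentage points apart, beyond the scatter of two such steps. In this assay, the high number belongs to tert-butyl and furan-2-yl together in compound 2, not to either group alone.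

Still open, from the compounds shown here alone, is whether an isopropyl ester or a free carboxylic acid on this carbonyl would keep that high number with furan-2-yl or restore it with furan-3-yl.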